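Swapping the Anilide Ring Substituent in a Dopamine D4 Agonist Series

The source may hold more compounds than are shown below. What is called first, only, known or untested is meant among the compounds shown, and "the series" means these compounds.

Of the compounds shown here, three sharing one core have been tested in a functional assay on HEK293 cells for agonist activity at D(4) dopamine receptor (Homo sapiens), read by FLIPR; a higher number here means that more compound is needed for the effect, a lower number that less compound is needed. Compound 1 `O=C(CN1CCC(c2cccc[n+]2[O-])CC1)Nc1cccc(Cl)c1` gives 62 nM, the lowest number of the three. Compound 3 `Cc1ccc([N+](=O)[O-])cc1NC(=O)CN1CCC(c2cccc[n+]2[O-])CC1` gives 134 nM, and compound 2 `COc1cccc(C(=O)NCN2CCC(c3cccc[n+]3[O-])CC2)c1C` gives 685 nM, both beyond the usual scatter from compound 1. Compound 4 `O=C(CN1CCC(c2cccc[n+]2[O-])CC1)Nc1ccc(F)cc1` has not been measured. It differs from compound 1 in one place: 4-fluorophenyl in place of 3-chlorophenyl on an amide-type nitrogen. Going by the values given here, no measured pair shows this exact change, so the expectation rests on compound 1 alone and is uncertain. A modest rise in the number is expected, a 2.4-fold higher number from compound 1 to compound 4 (0.38 log units; beyond the scatter), meaning somewhat more compound needed. Compound 4 is therefore estimated at 150 nM, with a likely range from 50 nM to 500 nM in this assay.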

Compound 4, half-maximal effective concentration: 85 nM
Compound 4: the middle estimate sits 1.8-fold (0.25 log units) above what was measured; the measured number falls inside the stated range.
By their numbers in this assay, from the lowest: compounds 1, 4 and 3 (each within the scatter of the next, the first and the last beyond it); then compound 2.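

Putting 4-fluorophenyl in place of 3-chlorophenyl on the amide-type nitrogen gives a 1.4-fold higher number from compound 1 to compound 4 (0.14 log units; within the scatter) in this assay, so compound 1 and compound 4 cannot be told apart at this position. This one step swaps the halogen and its ring position together, so it cannot show the effect of either alone. Nothing measured here offers a reason for this result. Still open, on these data alone, is whether the same tolerance holds for very different groups on this ring. A phenyl ring carrying an amine or a carboxylic acid in place of the halogen would test that.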